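The source may report more compounds than this note shows. Statements on the series, on what has been measured and on what is new or still open speak of the compounds shown alone.

The study concerns a series built on one shared core and asks how much of each member the cells tolerate. The measure is a toxicity assay on C8166 cells (Homo sapiens) for cytotoxicity, read by MTT assay, with a stated time of 72 h; a higher number here means that more compound is tolerated, a lower number that less compound is tolerated. For the measured compounds named here, compound 1, with the structure `CS(=O)(=O)Oc1c(C(=O)NCc2ccc(F)cc2)nc(Br)c2cccnc12`, is the only member of the set for which a number is given: in this assay compound 1 gives 48000 nM. Two further compounds are known by structure alone. Compound 2, `NCCCNc1c(C(=O)NCc2ccc(F)cc2)nc(Br)c2cccnc12`, was entered in this assay but for compound 2 the outcome is "not determined" (no result reported). Compound 3, `O=C(NCc1ccc(F)cc1)c1nc(Br)c2cccnc2c1NCc1ccccc1`, was likewise entered in this assay but for compound 3 the outcome is "not determined" (no result reported). Compound 1 therefore stands alone as the reference point and no comparison between measured members can be drawn.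

The step of interest leads from compound 1 to compound 4, whose structure is `Cc1ccc(S(=O)(=O)Oc2c(C(=O)NCc3ccc(F)cc3)nc(Br)c3cccnc23)cc1`. The change is 4-methylphenyl in place of methyl on a sulfonyl sulfur, on the sulfonyl sulfur whose other neighbour is the oxygen on the aromatic ring. Going by the values given here, with no step between measured compounds available, the size of this one can only be guessed. The step of a 1.4-fold lower number from compound 1 to compound 4 (0.14 log units; within the scatter) is expected to be modest, at or just beyond the scatter, and if anything towards less compound being tolerated. Compound 4 is accordingly estimated to give 35000 nM in this assay, within a range from 14000 nM to 90000 nM.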

Compound 4, half-maximal cytotoxic concentration: 31000 nM
Compound 4: middle estimate off by 1.1-fold (0.05 log units), on the high side, within the range that was stated.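

In this assay, for the compounds shown here, placing 4-methylphenyl in place of methyl on the sulfonyl sulfur gives a 1.5-fold lower number from compound 1 to compound 4 (0.19 log units; within the scatter), and this is the first step in the set that can be read at all. It shows that, for this one pair, a six-membered aromatic ring of carbon only can enter on the sulfonyl sulfur without the reading moving beyond the usual scatter, so compound 1 and compound 4 cannot be told apart in how much of each the cells tolerate. No measurement is available that could explain this result.

Going by these compounds alone, the steps to compound 2 and compound 3 cannot be read, so a single pair remains the only guide to this position, and how an amine joined directly to the ring at this place would compare stays unknown. As far as these compounds go, it also remains open whether the same holds for other groups on the sulfonyl sulfur, such as a longer alkyl chain, or a phenyl ring carrying a carboxylic acid or a nitrile instead of the methyl of 4-methylphenyl.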